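A few compounds are considered here, and "the series" means these few. Any claim that something is new, unique, unknown or untested is made for them only; others in the source may bear on it.

Measured compounds:
Compound 1, `COC1=C(C)C(=O)/C(=C(O)/C=C/c2ccc(O)cc2)C(=O)C1(C)C`; in a functional assay on A549 cells (Homo sapiens) for cytotoxicity (a higher number here means that more compound is needed for the effect, a lower number that less compound is needed), compound 1 gives 3.1 ug/mL.
Compound 2, `COC1=C(C)C(=O)/C(=C(O)/C=C/c2ccc(F)cc2)C(=O)C1(C)C`; compound 2 gives 3.3 ug/mL.
Compound 3, `COC1=C(C)C(=O)/C(=C(O)/C=C/c2ccc(C)cc2)C(=O)C1(C)C`; compound 3 gives 4.3 ug/mL.

Compound 3 holds the highest of the three numbers, but both other compounds sit within the scatter of it: a 1.4-fold higher number from compound 1 to compound 3 (0.14 log units; within the scatter) and a 1.3-fold higher number from compound 2 to compound 3 (0.11 log units; within the scatter). The remaining step, a 1.1-fold higher number from compound 1 to compound 2 (0.03 log units; within the scatter), is also within the scatter. Hydroxy, fluoro and methyl on the aromatic carbon are thus not separated by these data.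

Compound 4, `C=Cc1ccccc1/C=C/C(O)=C1/C(=O)C(C)=C(OC)C(C)(C)C1=O`, is not yet measured. Against compound 3 the change is 2-vinylphenyl in place of 4-methylphenyl on a double-bonded chain carbon bound to a double-bonded chain carbon. For the measured compounds named here, no measured step bears directly on it: each of the three steps exchanges one group on the aromatic ring for another and leaves the rest of the molecule untouched, whereas here the whole aryl group is exchanged. Going by the values given here, the only guide is that aryl variation has so far not shifted the number, because a 1.4-fold higher number from compound 1 to compound 3 (0.14 log units; within the scatter), a 1.3-fold higher number from compound 2 to compound 3 (0.11 log units; within the scatter) and a 1.1-fold higher number from compound 1 to compound 2 (0.03 log units; within the scatter) all lie within the scatter. On that basis the expected step is a 1.1-fold lower number from compound 3 to compound 4 (0.03 log units; within the scatter), with no direction favoured, and the range is set wide for the untested change. Compound 4 is estimated at 4 ug/mL, between 1.8 ug/mL and 9 ug/mL.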

Compound 4, concentration for half-maximal effect: 2.2 ug/mL
For compound 4 the middle estimate is 1.8-fold (0.26 log units) above the measured one, and the stated range covers the measured number.
By their numbers in this assay, from the lowest: compounds 4, 1, 2 and 3 (each within the scatter of the next).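

In this assay, exchanging the whole aryl group on a double-bonded chain carbon bound to a double-bonded chain carbon, and not just one group on the ring, still gives steps that lie within the scatter: a 2.0-fold lower number from compound 3 to compound 4 (0.29 log units; within the scatter), a 1.5-fold lower number from compound 2 to compound 4 (0.18 log units; within the scatter) and a 1.4-fold lower number from compound 1 to compound 4 (0.15 log units; within the scatter). This position therefore accepts 2-vinylphenyl, with its double bond outside aromatic rings, without separating it from 4-hydroxyphenyl, 4-fluorophenyl or 4-methylphenyl, so the flat picture seen among the three earlier compounds now extends to a change of the aryl group itself. No supporting data bear on this result, and the reason for it stays unknown.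

As far as these compounds go, all four compounds carry a six-membered aromatic ring of carbon only at this position, so it remains open whether a pyridine ring, an aryl group bearing an amine or a carboxylic acid, or a longer alkyl chain in place of the aryl group would move the number beyond the scatter. The shown compounds also leave the shared core unchanged, so the effect of replacing its methoxy group, for instance with an ethoxy group, is open too.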